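The compounds below may be only part of what the source reports. "The series", "measured", "known", "first", "only" and "open" are said of these compounds alone.

Working notes on the series. Compound 3 `Clc1ccc(C2=NN(c3nc(-c4ccc(Br)cc4)cs3)C(c3ccc4c(c3)OCCO4)C2)cc1` gives 2230 nM in a functional assay on MCF7 cells (Homo sapiens) for antiproliferative activity, read by MTT assay, with a stated time of 48 h; a higher number here means a weaker inhibitor, a lower number a stronger inhibitor. Among the three measured compounds it stands second highest on that count: compound 2 `Cc1ccc(C2=NN(c3nc(-c4ccc(Br)cc4)cs3)C(c3ccc4c(c3)OCCO4)C2)cc1`, with 1590 nM, is nearest, the step of a 1.4-fold higher number from compound 2 to compound 3 (0.15 log units; within the scatter) lying within the scatter, and compound 1 `Fc1ccc(C2=NN(c3nc(-c4ccc(Br)cc4)cs3)C(c3ccc4c(c3)OCCO4)C2)cc1`, with 4200 nM, is furthest, the step of a 1.9-fold lower number from compound 1 to compound 3 (0.27 log units; within the scatter) also lying within the scatter. Going by the values given here, the one step that clears the scatter in this group is a 2.6-fold lower number from compound 1 to compound 2 (0.42 log units; beyond the scatter).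

Compound 4 `Brc1ccc(C2=NN(c3nc(-c4ccc(Br)cc4)cs3)C(c3ccc4c(c3)OCCO4)C2)cc1` differs from compound 3 by bromo in place of chloro on an aromatic carbon. Among the compounds with values here, the steps that bear on this exchange are those that already swap the group on the same aromatic carbon: a 1.9-fold lower number from compound 1 to compound 3 (0.27 log units; within the scatter) and a 1.4-fold higher number from compound 2 to compound 3 (0.15 log units; within the scatter), both within the scatter. The shared core has so far tolerated fluoro, methyl and chloro at this position with little movement beyond that of compound 1 to compound 2. No step beyond the scatter is therefore expected for bromo; if anything, a small drift in the direction set by compound 1 to compound 3. The expected step is estimated as a 1.2-fold lower number from compound 3 to compound 4 (0.09 log units; within the scatter). The estimate for compound 4 is 1800 nM, with a range of 700 nM to 4500 nM.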

Compound 4, half-maximal inhibitory concentration: 320 nM
Compound 4: the middle estimate sits 5.6-fold (0.75 log units) above what was measured; measured number below the stated range.
By their numbers in this assay, from the lowest: compound 4; then compounds 2, 3 and 1 (each within the scatter of the next, the first and the last beyond it).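

In this assay, going by these compounds alone, the group para to a large group matters more than the earlier compounds showed: bromo stands apart from all three others, with a 7.0-fold lower number from compound 3 to compound 4 (0.84 log units; beyond the scatter) and a 5.0-fold lower number from compound 2 to compound 4 (0.70 log units; beyond the scatter) and also a 13-fold lower number from compound 1 to compound 4 (1.12 log units; beyond the scatter) beyond the scatter. Fluoro, methyl and chloro gave no hint of this, and the change from 4-chlorophenyl to 4-bromophenyl, a single heavy atom exchanged for another with no change in hydrogen-bond donors, acceptors or charge, moves the number further than any step among them. No measurement at hand accounts for this gain.

Open, on these data alone, is whether iodo, trifluoromethyl, methoxy or an amine at this place would follow bromo or fall back with the other three. Also open, as far as these compounds go, is whether the gain with bromo holds on any core other than the shared one.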